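Trading a Chlorinated Ring for Pyridine at the Ring Amine

The source may hold more compounds than are shown below. What is called first, only, known or untested is meant among the compounds shown, and "the series" means these compounds.

Of the compounds shown here, three sharing one core have been measured in an assay on HEK293 cells for agonist activity at Toll-like receptor 8 (Homo sapiens), read by a luciferase reporter, with a stated time of 6 h; on this read-out lower numbers stand for an effect already at smaller amounts and higher numbers for an effect only at larger amounts of compound. Compound 1 `CCCCNc1nc(N)nc2c1CCN(S(C)(=O)=O)C2` carries a methanesulfonyl group on the ring amine and gives 0.8 uM. Compound 2 `CCCCNc1nc(N)nc2c1CN(Cc1ccccc1Cl)CC2` carries a 2-chlorobenzyl group there and gives 0.05 uM. Compound 3 `CCCCNc1nc(N)nc2c1CN(Cc1ccc(C(F)(F)F)cc1)CC2` carries a 4-(trifluoromethyl)benzyl group and gives 0.23 uM. Compound 2 stands lowest of the three numbers; its gap to compound 3 and its larger gap to compound 1 both lie beyond the usual scatter, so within this small set it is the most potent compound.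

The step under consideration leads from compound 2 to compound 4 `CCCCNc1nc(N)nc2c1CN(Cc1ccncc1)CC2`, which has not yet been measured in this assay. The structural change is pyridin-4-yl in place of 2-chlorophenyl on a saturated chain carbon bound to an amine nitrogen in a ring. The same difference, cut one bond further out, reads 2-chlorobenzyl to (pyridin-4-yl)methyl.

For the measured compounds named here, no measured pair shows this exact change, so the expectation rests on the spread among the three measured compounds alone. Given that compound 3, with a different group on the same ring amine, gives 0.23 uM, the author expects the pyridin-4-yl compound to sit nearer that number than to compound 2. The step from compound 2 to compound 4 in this assay is expected to be a 10-fold higher number from compound 2 to compound 4 (1.00 log units; beyond the scatter), a rise beyond the scatter. Compound 4 is therefore estimated at 0.5 uM, with a likely range from 0.15 uM to 2 uM.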

Compound 4, minimum effective concentration: 0.29 uM
Estimate against measurement, compound 4: 1.7-fold (0.24 log units) above, within the range that was stated.
By their numbers in this assay, from the lowest: compound 2; then compounds 3 and 4 (each within the scatter of the next); then compound 1.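

In this assay, for the compounds shown here, putting pyridin-4-yl in place of 2-chlorophenyl on a saturated chain carbon bound to an amine nitrogen in a ring gives a 5.8-fold higher number from compound 2 to compound 4 (0.76 log units; beyond the scatter), the first reading of a single change at this position that starts from its lowest-numbered compound. Compound 3 at 0.23 uM and compound 4 at 0.29 uM lie within the scatter of each other, so two quite different aromatic rings on this carbon land at one level, while the 2-chlorobenzyl group of compound 2 stands apart from both. No measurement at hand explains this step.

The change removes the chlorine and brings in the ring nitrogen at once, and the compounds shown leave open which of the two goes with the higher number; a plain unsubstituted benzyl group on the ring amine would separate them. Also open, from the compounds shown here alone, is whether pyridin-2-yl or pyridin-3-yl on the same carbon would read like compound 4, and whether a 2-chloropyridin-4-yl group would recover the level of compound 2.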